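The source may hold more compounds than are shown below. What is called first, only, known or untested is meant among the compounds shown, and "the series" means these compounds.

Measured so far:
- compound 1 `CCc1nc(NC(CC)CC)c(OC)nc1-c1ccc(OC(F)F)cc1Cl`: 1.4 nM
- compound 2 `CCOc1nc(-c2ccc(Cl)cc2Cl)c(CC)nc1NC(CC)CC`: 151 nM

Both compounds were tested in an assay on IMR-32 cells for displacement of a labelled ligand from corticotropin-releasing factor receptor 1 (Homo sapiens), read by scintillation counting, with a stated time of 2 h; on this read-out lower numbers stand for stronger inhibition and higher numbers for weaker inhibition. Compound 2 stands at the higher of the two numbers, so it is the weaker binder of the pair, and its gap to compound 1 lies well beyond the ordinary scatter of repeat measurements. The two compounds differ in more than one place, so no single change can be credited for that gap.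

Compound 3 `CCc1nc(NC(CC)CC)c(OC)nc1-c1ccc(Cl)cc1Cl` is obtained from compound 2 by one change: hydrogen in place of methyl on a saturated chain carbon bound to an oxygen on an aromatic ring, that is, ethoxy becomes methoxy on the shared core. Nothing measured here isolates this change, so the expectation rests on how small the change is. A modest step is expected from compound 2 to compound 3, most likely toward a somewhat lower number, though a result within the scatter would not surprise. Compound 3 is therefore estimated at 50 nM, with a range from 10 nM to 250 nM, an expected step of a 3.0-fold lower number from compound 2 to compound 3 (0.48 log units; beyond the scatter).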

Compound 3, inhibition constant: 5.9 nM
Compound 3: middle estimate off by 8.5-fold (0.93 log units), on the high side; measured number below the stated range.
By their numbers in this assay, from the lowest: compound 1; then compound 3; then compound 2.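

Changing ethoxy to methoxy on the shared core gives in this assay a 26-fold lower number from compound 2 to compound 3 (1.41 log units; beyond the scatter) and so shows that removing a single methyl from this saturated chain can shift binding by a large amount. With methoxy in both compounds, chloro in place of difluoromethoxy on an aromatic carbon gives a 4.2-fold higher number from compound 1 to compound 3 (0.62 log units; beyond the scatter) and this step is modest, while the ethoxy to methoxy step is large. Nothing measured here explains why one methyl at this place matters so much.

On these data alone, it remains open what a longer chain such as propoxy, or a hydroxyl or an amine in place of the methoxy, would do at this place. As far as these compounds go, it is also open whether ethoxy would cost as much in a compound carrying difluoromethoxy, since a single step at this place cannot show that.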